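Hydroxyalkyl side chain and half-life in buffer

The source may hold more compounds than are shown below. What is called first, only, known or untested is meant among the compounds shown, and "the series" means these compounds.

compound 1 `CC(C)(C)C1=C(C(=O)O)N2C(=O)[C@H]([C@H](O)c3ccccc3)[C@H]2O1` — 7 h
compound 2 `C[C@@H](O)[C@H]1C(=O)N2C(C(=O)O)=C(C(C)(C)C)O[C@@H]12` — 6.4 h
compound 3 `C[C@H](O)[C@H]1C(=O)N2C(C(=O)O)=C(C(C)(C)C)O[C@H]12` — 7.1 h

In an ADME assay, in phosphate buffer, at 28 degrees C, at pH 7.0 (a lower number here means that the compound disappears faster, a higher number that the compound lasts longer), compound 3 gives 7.1 h; the three measured numbers all lie within the scatter of one another. Among the compounds with values here, the only measured step, a 1.1-fold higher number from compound 2 to compound 3 (0.05 log units; within the scatter), is within the scatter, and because the fact that compounds 2 and 3 differ only in the configuration as drawn it shows that configuration alone does not move the half-life. Compound 4 `CC(C)(C)C1=C(C(=O)O)N2C(=O)[C@H]([C@@H](O)CCc3ccccc3)[C@H]2O1` is not yet measured; it differs from compound 3 by benzyl in place of hydrogen on a saturated chain carbon, two bonds along the chain from an oxygen on a saturated carbon and a saturated ring carbon. Within the data shown here, no measured step covers this change, but compound 1, whose side chain also bears an aromatic ring, gives 7 h, close to the number of compound 3. The step of a 1.0-fold lower number from compound 3 to compound 4 (0.01 log units; within the scatter) is therefore expected to stay within the scatter. Compound 4 is estimated at 7 h, range 4 h to 12 h.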

Compound 4, half-life: 39 h
For compound 4 the middle estimate is 5.6-fold (0.75 log units) below the measured one, outside the stated range (above it).
By their numbers in this assay, from the lowest: compounds 2, 1 and 3 (each within the scatter of the next); then compound 4.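

Within the data shown here, at this saturated chain carbon, the position is not silent in this assay: benzyl in place of hydrogen gives a 5.5-fold higher number from compound 3 to compound 4 (0.74 log units; beyond the scatter), the only step beyond the scatter. An aromatic ring in the side chain does not by itself go with the longer half-life: compound 1 also carries one and gives 7 h, while compound 4 gives 39 h. Nothing measured in the series gives a reason for this rise. Still open, going by these compounds, is whether a longer chain ending in the same aromatic ring keeps this half-life, and whether an amine or a carboxylic acid at the chain end in place of that ring does the same.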